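This account rests on a few compounds, and the source may have more. Where it says the series, first, only, none or still open, it means among the compounds named here.

Compound 1 `CCCCNC(=O)N1CC1C#N` is one of three compounds whose numbers in a functional assay on RPMI-8226 cells (Homo sapiens) for inhibition (a lower number here means a stronger inhibitor, a higher number a weaker inhibitor), are known. In this assay compound 1 gives 17000 nM. Compound 2 `N#CC1CN1C(=O)Nc1ccc([N+](=O)[O-])cc1` gives 8600 nM, and compound 3 `N#CC1CN1C(=O)Nc1ccccc1` gives 8000 nM. Of the three, compound 1 has the highest number; its gap to compound 2 lies within the scatter, while its gap to compound 3 lies just beyond it. Among the measured compounds shown here, the only step between measured compounds that differ in one place, a 1.1-fold lower number from compound 2 to compound 3 (0.03 log units; within the scatter), lies within the scatter and changes an aromatic substituent on the other end of the shared core.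

Compound 4 `CCNC(=O)N1CC1C#N` differs from compound 1 in one place: hydrogen in place of ethyl on a saturated chain carbon, two bonds along the chain from an amide-type nitrogen. For the measured compounds named here, no measured step touches this part of the structure, so no step among the measured compounds bears directly on it. The shared core carries a nitrile and a urea-type carbonyl, and the three measured compounds sit together within a narrow band of numbers. Without a step that speaks to a shorter or longer chain at this place, the expectation is a step no larger than the scatter, in no particular direction. Compound 4 is therefore expected to give 20000 nM, within a range from 7000 nM to 60000 nM. That estimate means a step of a 1.2-fold higher number from compound 1 to compound 4 (0.07 log units; within the scatter).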

Compound 4, half-maximal inhibitory concentration: 26000 nM
Compound 4: the middle estimate sits 1.3-fold (0.11 log units) below what was measured; measured number inside the range.
By their numbers in this assay, from the lowest: compounds 3, 2, 1 and 4 (each within the scatter of the next, the first and the last beyond it).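

In this assay, going from a butyl chain to an ethyl chain on the urea-type nitrogen gives a 1.5-fold higher number from compound 1 to compound 4 (0.18 log units; within the scatter). Among the compounds shown here, this is the first measured step at this part of the structure, since the only earlier step concerned a substituent on the aromatic ring, and it shows that losing these two chain carbons produces no difference that can be told apart from the ordinary spread of repeated measurements. No measurement of any property accompanies this step, so the data offer no account of what lies behind the result.

One step at one position cannot show whether chain length matters at all here, and a much longer chain such as octyl, or a very short one such as methyl, might behave differently from the butyl and ethyl pair. On these data alone, it also remains open whether an amine or a carboxylic acid at the end of the chain, or a cyclohexyl ring in its place, would move the number beyond the scatter in either direction.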